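Amide chain extension from compound 1 to compound 4

The source may report more compounds than this note shows. Statements on the series, on what has been measured and on what is new or still open speak of the compounds shown alone.

In a functional assay on HepG2 cells (Homo sapiens) for cytotoxicity (a lower number here means that less compound is tolerated, a higher number that more compound is tolerated), compound 1 (`CCCCCC(=O)Nc1nc(N)nc2c1ncn2[C@H]1CO[C@@H](CO)O1`) gives > 100000 nM, which is a limit. Compound 2 (`CCCCCCCCCC(=O)Nc1nc(N)nc2c1ncn2[C@H]1CO[C@@H](CO)O1`) gives > 100000 nM, also a limit. Compound 3 (`CCCCCCCCCCCC(=O)Nc1nc(N)nc2c1ncn2[C@H]1CO[C@@H](CO)O1`) gives > 100000 nM, again a limit. All three sit at the limit of > 100000 nM in this assay, at which 3 of the 3 values shown sit.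

Compound 4 (`CCCCCCCC/C=C\CCCCCCCC(=O)Nc1nc(N)nc2c1ncn2[C@H]1CO[C@@H](CO)O1`) carries dodec-3-en-1-yl in place of hydrogen on a saturated chain carbon, five bonds along the chain from a carbonyl carbon. The closest measured changes are a step that the two limits leave unreadable from compound 1 to compound 2 and a step that the two limits leave unreadable from compound 1 to compound 3, and a step that the two limits leave unreadable from compound 2 to compound 3 adds no readable size either. From these steps, no change beyond the scatter is expected in this assay, and no direction is favoured. The expected step is a number no higher from compound 1 to compound 4 (the limit leaves the size open). For compound 4 the estimated value is 100000 nM, with an expected range of 50000 nM to 200000 nM.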

Compound 4, half-maximal cytotoxic concentration: 11000 nM
For compound 4 the middle estimate is 9.1-fold (0.96 log units) above the measured one, outside the stated range (below it).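

Going by these compounds alone, the dodec-3-en-1-yl group, on a saturated chain carbon five bonds along the chain from a carbonyl carbon, gives the first readable change at this position in this assay, with an at least 9.0-fold lower number from compound 1 to compound 4 (0.95 log units; beyond the scatter). The shorter saturated chains show the same gap, with an at least 9.0-fold lower number from compound 2 to compound 4 (0.95 log units; beyond the scatter) and with an at least 9.0-fold lower number from compound 3 to compound 4 (0.95 log units; beyond the scatter). Only compound 4 comes off the limit shared by the other compounds: the limit of > 100000 nM in this assay, at which 3 of the 4 values shown sit.

Open, as far as these compounds go, is whether the double bond or the added length goes with this step; a fully saturated chain of the same length would separate the two. From the compounds shown here alone, the effect of an amine on the chain also remains open.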